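Bromo in place of chloro on an aromatic carbon

The source may report more compounds than this note shows. Statements on the series, on what has been measured and on what is new or still open speak of the compounds shown alone.

Compound 1 `COc1cc(OC)c(C(=O)/C=C/c2ccccc2OC)c(OC)c1`: 4200 nM
Compound 2 `COc1cc(OC)c(C(=O)/C=C/c2ccc(Cl)cc2)c(OC)c1`: 5400 nM

Among the compounds with values here, only these two compounds have been measured in a functional assay on HCT-116 cells (Homo sapiens) for cytotoxicity, with a stated time of 48 h (on this read-out lower numbers stand for stronger inhibition and higher numbers for weaker inhibition), and compound 2 stands level with compound 1, since the one step between them is a 1.3-fold higher number from compound 1 to compound 2 (0.11 log units; within the scatter). Next is compound 3 `COc1cc(OC)c(C(=O)/C=C/c2ccc(Br)cc2)c(OC)c1`, which keeps everything in compound 2 except one atom: bromo in place of chloro on an aromatic carbon. The swap sits para to a large group. Within the data shown here, no measured step replaces chloro by bromo, so the evidence is indirect. The nearest guide is the exchange of 2-methoxyphenyl for 4-chlorophenyl, a larger change that still amounted only to a 1.3-fold higher number from compound 1 to compound 2 (0.11 log units; within the scatter). A step within the scatter, with no clear direction, is therefore expected in this assay. The estimated outcome is a 1.1-fold lower number from compound 2 to compound 3 (0.03 log units; within the scatter). For compound 3 the expected value is 5000 nM, with an estimated range of 2500 nM to 10000 nM.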

Compound 3, half-maximal inhibitory concentration: 6200 nM
The estimate for compound 3 lay 1.2-fold (0.09 log units) below the measured number; the range from low to high includes it.
By their numbers in this assay, from the lowest: compounds 1, 2 and 3 (each within the scatter of the next).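

In this assay, within the data shown here, the exchange of chloro for bromo on this aromatic carbon, para to a large group, gives a 1.1-fold higher number from compound 2 to compound 3 (0.06 log units; within the scatter), which is the first direct reading of one halogen against another at this position. The exchange of 2-methoxyphenyl for 4-bromophenyl gives a 1.5-fold higher number from compound 1 to compound 3 (0.17 log units; within the scatter), so all three compounds remain within the scatter of one another, and neither halogen can be ranked above the other or above the 2-methoxyphenyl compound. No measurement is available that could explain these readings.

Open, from the compounds shown here alone, is whether any group of a different kind on this aromatic carbon, such as an amine, a carboxylic acid or a longer alkyl chain, would give a step beyond the scatter. These three compounds cover only chloro, bromo and 2-methoxyphenyl, so they cannot show how far this level reading extends.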